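Fluoro for bromo on the core of compound 3

The source may hold more compounds than are shown below. What is called first, only, known or untested is meant among the compounds shown, and "the series" means these compounds.

The series is followed in a functional assay on cells for positive allosteric modulation of metabotropic glutamate receptor 2 (Homo sapiens), read by fluorescence and calcium flux, with a stated time of 30 min; on this read-out lower numbers stand for an effect already at smaller amounts and higher numbers for an effect only at larger amounts of compound. Compound 1 `Clc1ccc(-c2ccc(Cn3nnc4ccccc43)cn2)cc1` gives 70 nM. Compound 2 `Brc1cccc2c1nnn2CC1CC1` gives 70 nM in this assay. Compound 3 `Brc1cc(Br)c2nnn(CC3CC3)c2c1` gives 50 nM, the lowest of the three numbers, yet within the scatter of compound 1 and of compound 2 alike, so no order among the three can be read from this assay. Within the data shown here, the one single-point step measured so far, a 1.4-fold lower number from compound 2 to compound 3 (0.15 log units; within the scatter), came from a bromo in place of hydrogen on an aromatic carbon. Compound 4 `Fc1cc(Br)c2nnn(CC3CC3)c2c1` differs from compound 3 by fluoro in place of bromo on an aromatic carbon; the bromo that leaves sits meta to a bromo group, meta to a fused ring and para to a fused ring. Among the measured compounds shown here, the only step bearing on this position is the one from compound 2 to compound 3, which stayed inside the scatter; a fluoro there is untested, so no step beyond the scatter is expected in this assay in either direction. On that basis compound 4 is estimated at 65 nM, with a range of 25 nM to 180 nM. The step expected, a 1.3-fold higher number from compound 3 to compound 4 (0.11 log units; within the scatter), is thus within the scatter.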

Compound 4, half-maximal effective concentration: 70 nM
Compound 4: middle estimate off by 1.1-fold (0.03 log units), on the low side; the range from low to high includes it.
By their numbers in this assay, from the lowest: compounds 3, 1, 2 and 4 (each within the scatter of the next).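

In this assay this position has now been seen with hydrogen, bromo and fluoro on the same core, and both new steps stay inside the scatter: a 1.4-fold higher number from compound 3 to compound 4 (0.15 log units; within the scatter) and no change at the digits printed from compound 2 to compound 4 (within the scatter). Replacing one halogen with another therefore shows no readable effect here, and fluoro in place of hydrogen shows none either, so hydrogen, bromo and fluoro cannot be ordered at this position. No evidence is at hand that would explain this flat result.

Still open, from the compounds shown here alone, is whether an amine, a carboxylic acid or a longer chain at this position would give a step beyond the scatter. The compounds shown also leave open what replacing the remaining bromo of compound 4 with such a group would do.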